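The source may hold more compounds than are shown below. What is called first, only, known or untested is meant among the compounds shown, and "the series" means these compounds.

Compound 1 `CCCCCCCCCCCCCCCC1=C(C)C(=O)C(OC)=C(OC)C1=O` gives 86% in a functional assay on CCRF-CEM cells (Homo sapiens), read by flow cytometry, using a membrane potential dye, with stated times of 16 h and 120 min, tested at 0.5 uM; a lower number here means a weaker effect, a higher number a stronger effect of the compound at the concentration tested. Compound 2 `COC1=C(OC)C(=O)C(CCCCCCCCC(C)(C)C)=C(C)C1=O` gives 70% in this assay.

Going by the values given here, compound 2 holds the lower of the two numbers, separated from compound 1 by the only measured step, a number 16 percentage points lower from compound 1 to compound 2 (beyond the scatter). Compound 3 `COC1=C(OC)C(=O)C(CCCCCCCCCCC2CCCCC2)=C(C)C1=O` differs from compound 2 by 2-cyclohexylethyl in place of tert-butyl on a saturated chain carbon, eight bonds along the chain from a double-bonded ring carbon. Among the compounds with values here, that single step is the only guide: shortening the tail to tert-butyl lowered the number, and compound 3 again carries a longer tail, ending in a ring rather than open chain. A rise of about that size is therefore expected, a number 12 percentage points higher from compound 2 to compound 3 (beyond the scatter), giving for compound 3 an estimated 82%, within 66% to 95%.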

Compound 3, a percentage reported as activity, at one concentration (the size of the read-out at that concentration, not a potency): 84%
For compound 3 the middle estimate is 2 percentage points below the measured one, within the range that was stated.
By their numbers in this assay, from the lowest: compound 2; then compounds 3 and 1 (each within the scatter of the next).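

In this assay, swapping tert-butyl for 2-cyclohexylethyl gives a number 14 percentage points higher from compound 2 to compound 3 (beyond the scatter) at this place on the chain, so a bulky end does not lower the number once the tail is longer. Cyclohexyl in place of pentyl gives a number 2 percentage points lower from compound 1 to compound 3 (within the scatter) here, so among these tails a ring end and an open-chain end read alike. Nothing available explains these numbers.

Going by these compounds, whether a tail ending in an amine or a carboxylic acid would keep the number stays open. So does the effect of a chain longer than that of compound 1.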